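A few compounds are considered here, and "the series" means these few. Any claim that something is new, unique, unknown or untested is made for them only; others in the source may bear on it.

Going by the values given here, the two compounds measured so far share one core: compound 1 `CCOC(=O)c1ccc(NC(=O)C(=O)c2ccccc2NC(C)=O)cc1` and compound 2 `COC(=O)CCNC(=O)C(=O)c1ccccc1NC(C)=O`. In an assay on mitochondria from liver for inhibition of Amine oxidase [flavin-containing] A (Rattus norvegicus), with a stated time of 60 min (a lower number here means a stronger inhibitor, a higher number a weaker inhibitor), compound 1 gives 83 nM, and compound 2 gives 33 nM. Of these two numbers, compound 1 has the higher one, so it is the weaker of the pair, and the gap to compound 2 lies beyond the usual scatter of this assay. The two compounds differ in more than one place, so their values show only that both inhibit in this range.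

Compound 3 `COC(=O)[C@@H](NC(=O)c1ccc(NC(=O)C(=O)c2ccccc2NC(C)=O)cc1)C(C)C` is not yet measured. It comes from compound 1 by a single change: (1-(methoxycarbonyl)-2-methylpropyl)amino in place of ethoxy on a carbonyl carbon. Among the compounds with values here, no measured pair shows this kind of change alone, so there is no direct precedent to lean on. The change adds a larger, more hydrogen-bonding group at a point where the remaining compounds carry only small ester ends. The expectation is that the step from compound 1 to compound 3 a 1.4-fold higher number from compound 1 to compound 3 (0.16 log units; within the scatter) will be small, with slight weakening more likely than strengthening, though a result within the scatter would not surprise. For compound 3 in this assay the estimated value is 120 nM, with a plausible range from 40 nM to 400 nM.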

Compound 3, half-maximal inhibitory concentration: 2.8 nM
The estimate for compound 3 lay 43-fold (1.63 log units) above the measured number; the whole stated range lies above it.
By their numbers in this assay, from the lowest: compound 3; then compound 2; then compound 1.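

In this assay, the carbonyl carbon whose other neighbour is an aromatic carbon proves to be a sensitive point: (1-(methoxycarbonyl)-2-methylpropyl)amino in place of ethoxy gives a 30-fold lower number from compound 1 to compound 3 (1.47 log units; beyond the scatter). The earlier pair could not show this, since those two compounds differ in more than one place and established only that both inhibit in a similar range; this single change shows that the ethoxy is not needed at this position, and that the larger group brings a large gain in inhibition here. No measurement at hand explains the size of this gain.

The change brings in several features at once, namely the amide hydrogen, the branched 2-methylpropyl part, the methyl ester and a defined stereocentre, so the compounds shown do not reveal which of them accounts for the step. A plain methylamino group at this position, a free carboxylic acid in place of the methoxycarbonyl, or the opposite configuration at the stereocentre would each test one of these features separately.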